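Fluoro Added to a Series Sitting Wholly at the Limit

The compounds below may be only part of what the source reports. "The series", "measured", "known", "first", "only" and "open" are said of these compounds alone.

Measured compounds:
- Compound 1 `O=C(Nc1ccc(Oc2ccnc3[nH]ccc23)cc1)c1ccc(-c2ccc(Cl)cc2)cn1`. In a functional assay on MCF7 cells (Homo sapiens) for cytotoxicity, read by MTT assay, with a stated time of 72 h (a higher number here means a weaker inhibitor, a lower number a stronger inhibitor), compound 1 gives > 10000 nM, a limit of the assay rather than a number.
- Compound 2 `CCc1ccc(-c2ccc(C(=O)Nc3ccc(Oc4ccnc5[nH]ccc45)cc3)nc2)cc1`. In this assay compound 2 gives > 10000 nM, again a limit.
- Compound 3 `Cc1ccc(-c2ccnc(C(=O)Nc3ccc(Oc4ccnc5[nH]ccc45)cc3)c2)cc1`. In this assay compound 3 gives > 10000 nM, also a limit.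

Compound 1 therefore stands nowhere in particular on the scale: its value is a limit, and the two further values shown are limits as well, so the whole set sits at the limit of > 10000 nM in this assay, at which 3 of the 3 values shown sit. Among the measured compounds shown here, the one step between compounds differing in a single place, a step that the two limits leave unreadable from compound 1 to compound 2, cannot be read for size or direction. Compound 1 and compound 3 differ in more than one place; their two values show only that both are limits.

Compound 4 `O=C(Nc1ccc(Oc2ccnc3[nH]ccc23)c(F)c1)c1ccc(-c2ccc(Cl)cc2)cn1` carries the change (fluoro in place of hydrogen on an aromatic carbon). No measured step bears readably on it, so no step beyond the scatter can be expected in this assay, in either direction, and the outcome most consistent with the shown values is another limit. Compound 4 is estimated at 20000 nM, with a range from 8000 nM to 60000 nM, which corresponds to an expected step that the limit leaves unreadable from compound 1 to compound 4.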

Compound 4, half-maximal inhibitory concentration: > 10000 nM
Compound 4 gave a limit, no number (the forecaster's own chance of this, stated with the estimate: 80%); the middle value lies beyond the limit too.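

Among the compounds shown here, with fluoro in place of hydrogen, compound 4 gives > 10000 nM in this assay, a limit and not a number; compound 1 is also a limit, so no step between compound 1 and compound 4 can be read. Whether fluoro shifts cytotoxicity at all, and where any of these compounds truly falls, stays open: the limit of > 10000 nM in this assay, at which 4 of the 4 values shown sit.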